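Adding a Methoxy Group to Compound 3

This account rests on a few compounds, and the source may have more. Where it says the series, first, only, none or still open, it means among the compounds named here.

Among the compounds with values here, only one of the three compounds tested so far on this shared core has given a usable result. In an ADME assay on HT-22 cells (Mus musculus) for cytotoxicity, read by MTT assay, with a stated time of 48 h (on this read-out lower numbers stand for higher toxicity in this test and higher numbers for lower toxicity in this test), compound 1 (`COc1ccc(N(C)c2ncnc3c2ncn3C)cc1`) has the entry "not determined" (no result reported) and so offers no reading. Compound 2 (`COc1ccc(N(C)c2ncnc3c2ncn3Cc2ccc(OC)c(OC)c2)cc1`) gives > 100000 nM as a limit of the assay and not as a number. Compound 3 (`COc1ccc(N(C)c2ncnc3c2ncn3Cc2cc(OC)cc(OC)c2)cc1`) has the entry "not determined" (no result reported) and therefore holds no place on the scale. No measured step connects any two of these compounds.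

Compound 4 (`COc1ccc(N(C)c2ncnc3c2ncn3Cc2cc(OC)c(OC)c(OC)c2)cc1`) differs from compound 3 at a single site (methoxy in place of hydrogen on an aromatic carbon). A methoxy group replaces a hydrogen on an aromatic carbon, ortho to two methoxy groups and para to a large group.

With so little data, the expected change in this assay from this addition is none beyond the usual scatter, and no direction is favoured. Within the data shown here, the only guide is compound 2, whose entry of > 100000 nM is a limit of the assay. Compound 4 may well return a limit too. As a number, the estimated half-maximal cytotoxic concentration of compound 4 is 100000 nM (expected range 40000 nM to 200000 nM) in this assay.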

Compound 4, half-maximal cytotoxic concentration: 23000 nM
Compound 4: the middle estimate sits 4.3-fold (0.64 log units) above what was measured; measured number below the stated range.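

Within the data shown here, compound 4 gives the first true number on the shared core, and it shows that replacing a hydrogen on this ring with a methoxy group can move the read-out: in this assay the change appears as an at least 4.3-fold lower number from compound 2 to compound 4 (0.63 log units; beyond the scatter), and a lower number here stands for higher toxicity in this test. The size of that step is only a floor, because compound 2 holds a limit of the assay and not a number: the limit of > 100000 nM in this assay, at which 1 of the 4 values shown sits. Compound 3 has no result, and the step from it to compound 4, the change named in the title, cannot be read.

The compounds shown leave open whether the lower number belongs to the methoxy group in particular or would also follow another group on this aromatic carbon, such as a hydroxyl group, an amine or a chlorine atom. They also do not tell whether compound 3, whose two methoxy groups are placed differently from those of compound 2, would sit nearer to compound 2 or to compound 4 on this scale.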